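Replacing the benzyl group of compound 3

A few compounds are considered here, and "the series" means these few. Any claim that something is new, unique, unknown or untested is made for them only; others in the source may bear on it.

In a functional assay on A-375 cells (Homo sapiens) for antiproliferative activity, read by MTT assay, with a stated time of 24 h (on this read-out higher numbers stand for weaker inhibition and lower numbers for stronger inhibition), compound 3 `COc1cc(OC)c(-c2coc3cc(OCc4ccccc4C(F)(F)F)ccc3c2=O)cc1OC` gives > 10000 nM, which is a limit of the assay and not a number. Compound 1 `COc1cc(OC)c(-c2coc3cc(OCC(=O)c4cccc(C(F)(F)F)c4)ccc3c2=O)cc1OC` gives > 10000 nM, which is also a limit. Compound 2 `COc1cc(OC)c(-c2coc3cc(OCc4ccc(F)cc4)ccc3c2=O)cc1OC` alone gives a true number, 1720 nM.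

Compound 4 `COc1cc(OC)c(-c2coc3cc(OCc4ccc(Cl)cc4)ccc3c2=O)cc1OC` differs from compound 3 as follows: 4-chlorophenyl in place of 2-(trifluoromethyl)phenyl on a saturated chain carbon bound to an oxygen on an aromatic ring. It thus carries 4-chlorophenyl, where compound 2 carries 4-fluorophenyl, on a saturated chain carbon bound to an oxygen on an aromatic ring.

Going by the values given here, two measured steps bear on this. The closer one is an at least 5.8-fold higher number from compound 2 to compound 3 (0.76 log units; beyond the scatter), and it involves the same leaving group. The other is an at least 5.8-fold lower number from compound 1 to compound 2 (0.76 log units; beyond the scatter). Both show compound 2 ahead of a compound at the limit, though neither reveals the full size of the gap. A step of at least similar size is therefore expected in the opposite direction to the first, towards stronger inhibition, resting on compound 2 and its 1720 nM. The expected change is an at least 4.5-fold lower number from compound 3 to compound 4 (0.65 log units; beyond the scatter). For compound 4 the estimated value is 2200 nM, with an expected range of 700 nM to 8000 nM.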

Compound 4, half-maximal inhibitory concentration: 1020 nM
The estimate for compound 4 lay 2.2-fold (0.33 log units) above the measured number; measured number inside the range.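

At the saturated chain carbon bound to an oxygen on an aromatic ring, 4-chlorophenyl gives a second true number in this assay, so compound 2 no longer stands alone among the compounds shown. Chloro in place of fluoro on an aromatic carbon gives a 1.7-fold lower number from compound 2 to compound 4 (0.23 log units; within the scatter), so this change does not separate the two halogens. Against the two other compounds, the result is an at least 9.8-fold lower number from compound 3 to compound 4 (0.99 log units; beyond the scatter) and an at least 9.8-fold lower number from compound 1 to compound 4 (0.99 log units; beyond the scatter), and the full size of these steps, like the step between those two compounds, cannot be read because of the limit: the limit of > 10000 nM in this assay, at which 2 of the 4 values shown sit.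

The compounds shown leave open whether compound 3 differs from compound 4 through the trifluoromethyl group itself or through where it sits. On these data alone, it also remains open how a benzyl group carrying an amine or a carboxylic acid would behave at this carbon.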